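A few compounds are considered here, and "the series" means these few. Any claim that something is new, unique, unknown or untested is made for them only; others in the source may bear on it.

Compound 1 `Cc1c(F)cc(F)cc1[C@@H](C)N(C(=O)c1ccccc1)[C@@H](C(N)=O)c1ccccc1` gives 2000 nM in an assay on HEK293T cells for antagonist activity at transient receptor potential cation channel subfamily M member 8 (Homo sapiens), read by fluorescence and calcium flux, with a stated time of 60 min; a higher number here means a weaker inhibitor, a lower number a stronger inhibitor.
Compound 2 `C[C@H](c1ccccc1)N(C(=O)c1ccccc1)[C@@H](C(N)=O)c1ccccc1` gives 1200 nM in this assay.

Among the compounds with values here, compound 2 has the lowest of the two numbers recorded so far, but its only neighbour is compound 1, and the step of a 1.7-fold lower number from compound 1 to compound 2 (0.22 log units; within the scatter) lies within the scatter, so the two compounds cannot be ranked against each other. Compound 3 `NC(=O)[C@@H](c1ccccc1)N(C(=O)c1ccccc1)[C@@H]1COc2ccccc21` is the next compound to be measured in this assay. It differs from compound 2 in a single place: a group of 9 heavy atoms (8 carbon, 1 oxygen; one five-membered non-aromatic ring with 1 hetero atom, one six-membered aromatic ring of carbon only) in place of a group of 8 heavy atoms (8 carbon; one six-membered aromatic ring of carbon only), on an amide-type nitrogen. Within the data shown here, no measured step bears directly on this change; the only step recorded, from compound 1 to compound 2, alters the phenyl part of the 1-phenylethyl group and not the group that is now exchanged. There is therefore no basis for expecting a shift in this assay beyond the scatter in either direction. Compound 3 is accordingly estimated at 1200 nM, with a range from 400 nM to 3600 nM. The expected step of no change at the digits printed from compound 2 to compound 3 (within the scatter) thus amounts to no change beyond the scatter.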

Compound 3, half-maximal inhibitory concentration: 3300 nM
For compound 3 the middle estimate is 2.8-fold (0.44 log units) below the measured one; measured number inside the range.
By their numbers in this assay, from the lowest: compounds 2, 1 and 3 (each within the scatter of the next, the first and the last beyond it).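

Putting the group with a five-membered non-aromatic ring in place of 1-phenylethyl on the amide-type nitrogen gives a 2.8-fold higher number from compound 2 to compound 3 (0.44 log units; beyond the scatter) in this assay. This is the only step shown that lies beyond the scatter, so this position registers a change where the earlier step did not separate its compounds. The entering group differs from 1-phenylethyl both in its ring and in its hydrogen-bond acceptor, and nothing shown separates these two differences or accounts for the higher number.

From the compounds shown here alone, it remains open whether a benzyl group or a longer alkyl chain on this nitrogen would stay within the scatter of compound 2. Going by these compounds, the benzoyl group and the primary amide are also unchanged throughout, so what a pyridine ring or a carboxylic acid would do in those places is unknown.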